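The compounds below may be only part of what the source reports. "The series", "measured", "known", "first", "only" and "open" are said of these compounds alone.

Compound 1 `COc1ccc(-c2nc3ccccc3s2)cc1OC` gives the highest number of the three measured compounds in a functional assay on KM12 cells (Homo sapiens) for antiproliferative activity (on this read-out higher numbers stand for weaker inhibition of growth and lower numbers for stronger inhibition of growth), at 74200 nM. Compound 2 `COc1ccc(-c2nc3cc(Cl)ccc3s2)cc1OC` gives 12400 nM in this assay, and compound 3 `COc1ccc(-c2nc3ccc(F)cc3s2)cc1OC` gives 24100 nM. Compound 4 `COc1ccc(-c2nc3c(F)cccc3s2)cc1OC` differs from compound 1 by fluoro in place of hydrogen on an aromatic carbon, placed on an aromatic carbon ortho to a fused ring. The two measured steps bear on it: a 6.0-fold lower number from compound 1 to compound 2 (0.78 log units; beyond the scatter) and a 3.1-fold lower number from compound 1 to compound 3 (0.49 log units; beyond the scatter). Both halogen substitutions on the core lowered the number beyond the scatter, but neither sits at the position used in compound 4, so the step is expected to be modest and downward. Compound 4 is therefore expected to give 40000 nM, within a range of 15000 nM to 110000 nM, meaning an estimated 1.9-fold lower number from compound 1 to compound 4 (0.27 log units; within the scatter).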

Compound 4, concentration for 50% growth inhibition: 850 nM
Beside the measured number, compound 4's estimate is 47-fold (1.67 log units) above it; the whole stated range lies above it.
By their numbers in this assay, from the lowest: compound 4; then compounds 2 and 3 (each within the scatter of the next); then compound 1.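

In this assay fluoro on the aromatic carbon ortho to a fused ring gives an 87-fold lower number from compound 1 to compound 4 (1.94 log units; beyond the scatter) while the same change elsewhere on the core gives only a 3.1-fold lower number from compound 1 to compound 3 (0.49 log units; beyond the scatter). Among these compounds, the size of the step therefore depends on where the fluoro stands on the core, not merely on a halogen being present. Nothing available explains this difference. As far as these compounds go, whether chloro or an amine at this same position would give a step of similar size stays open. Also open, from the compounds shown here alone, is whether fluoro here would combine with the chloro of compound 2.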